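Same atoms, rearranged chain: a forecast for compound 4

A few compounds are considered here, and "the series" means these few. Any claim that something is new, unique, unknown or untested is made for them only; others in the source may bear on it.

In a functional assay on HeLa cells (Homo sapiens) for cytotoxicity, read by WST assay, with a stated time of 48 h (a lower number here means a stronger inhibitor, a higher number a weaker inhibitor), compound 1 (`COc1cc(C(c2ccc(O)c(OC)c2)[C@@H](C)C(C)C)ccc1O`) gives 19000 nM. Compound 2 (`COc1cc(C(c2ccc(O)c(OC)c2)[C@H](CC(C)C)C(C)C)ccc1O`) gives 8200 nM, which is a 2.3-fold lower number from compound 1 to compound 2 (0.36 log units; beyond the scatter). Compound 3 (`COc1cc(C(c2ccc(O)c(OC)c2)[C@H](C)[C@@H](C)CO)ccc1O`), which carries a hydroxymethyl group in its chain, has no exact number, only a limit of > 100000 nM.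

Compound 4 (`COc1cc(C(c2ccc(O)c(OC)c2)[C@H](CO)C(C)C)ccc1O`) differs from compound 3 only in the chain on a saturated chain carbon bound to two aromatic carbons: 1-(hydroxymethyl)-2-methylpropyl in place of 2-(hydroxymethyl)-1-methylpropyl on a saturated chain carbon bound to two aromatic carbons. The two have the same atoms, joined differently, and the hydroxymethyl group remains.

Among the measured compounds shown here, no measured step moves such a group within a chain. The nearest guides are the two steps that bring one in: an at least 5.2-fold higher number from compound 1 to compound 3 (0.72 log units; beyond the scatter), and an at least 12-fold higher number from compound 2 to compound 3 (1.08 log units; beyond the scatter). Both run toward weaker inhibition. Since compound 4 keeps the group, it is expected to stay a weak inhibitor, closer to compound 3 than to compound 1 or compound 2, though this rests on very few compounds.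

The step expected in this assay is small: an at least 1.6-fold lower number from compound 3 to compound 4 (0.22 log units; that floor lies within the scatter). For compound 4 the estimated value is 60000 nM, with an expected range from 20000 nM to 150000 nM.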

Compound 4, half-maximal inhibitory concentration: > 100000 nM
Compound 4: no number, only a limit; the forecaster's own chance of this, stated with the estimate: 50%; at least 1.6-fold (0.22 log units) between middle value and limit.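

Moving the hydroxymethyl group within the chain does not bring back measurable inhibition in this assay: with 1-(hydroxymethyl)-2-methylpropyl on the saturated chain carbon bound to two aromatic carbons, there is an at least 5.2-fold higher number from compound 1 to compound 4 (0.72 log units; beyond the scatter), and likewise an at least 12-fold higher number from compound 2 to compound 4 (1.08 log units; beyond the scatter). Until now, only compound 3 linked a hydroxymethyl-bearing chain with weak inhibition at this position; compound 4 now shows the same for a second arrangement of the same atoms, while compound 1 and compound 2, whose chains lack the group, both give exact values. The step between compound 3 and compound 4 cannot be read, and neither arrangement can be called the better one, because both results are limits rather than numbers: the limit of > 100000 nM in this assay, at which 2 of the 4 values shown sit.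

Going by these compounds, how far compound 3 and compound 4 actually lie from each other, and from that limit, stays open. So does the question of whether an amine or a carboxylic acid in place of the hydroxy of this chain, or a longer chain carrying the hydroxy, would read the same way on the shared core.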